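A few compounds are considered here, and "the series" means these few. Any claim that something is new, unique, unknown or untested is made for them only; others in the source may bear on it.

Compound 1 `COc1ccc(C(=O)Nc2cccc(-c3oc4cc(-c5ccc(F)cc5)ccc4c(=O)c3O)c2)cc1` gives 8700 nM in a functional assay on A549 cells (Homo sapiens) for antiproliferative activity, read by CCK-8 assay, with a stated time of 72 h; a higher number here means a weaker inhibitor, a lower number a stronger inhibitor. Compound 2 `O=C(Nc1cccc(-c2oc3cc(-c4ccc(F)cc4)ccc3c(=O)c2O)c1)c1ccc(Cl)cc1` gives 10800 nM in this assay. Compound 3 `O=C(Nc1cccc(-c2oc3cc(-c4ccc(F)cc4)ccc3c(=O)c2O)c1)c1ccc(Br)cc1` gives 13500 nM in this assay.

Compound 3 holds the highest of the three numbers, but its nearest neighbour, compound 2, sits only a step of a 1.3-fold higher number from compound 2 to compound 3 (0.10 log units; within the scatter) away, and compound 1 a step of a 1.6-fold higher number from compound 1 to compound 3 (0.19 log units; within the scatter), so the three numbers are within the scatter of one another and cannot be ordered.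

Compound 4 `COc1cccc(C(=O)Nc2cccc(-c3oc4cc(-c5ccc(F)cc5)ccc4c(=O)c3O)c2)c1` differs from compound 3 as follows: 3-methoxyphenyl in place of 4-bromophenyl on a carbonyl carbon. The measured step that bears most on this is a 1.6-fold higher number from compound 1 to compound 3 (0.19 log units; within the scatter), which exchanged methoxy for bromo and was within the scatter; the step of a 1.2-fold higher number from compound 1 to compound 2 (0.09 log units; within the scatter) points the same way. Within the data shown here, no measured pair tests a 3-methoxyphenyl, so that part of the change is untested. The expected step of a 1.5-fold lower number from compound 3 to compound 4 (0.18 log units; within the scatter) in this assay is therefore small, at most a slight lowering of the number. Compound 4 is estimated at 9000 nM, with a range from 4500 nM to 18000 nM.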

Compound 4, half-maximal inhibitory concentration: 10800 nM
Estimate against measurement, compound 4: 1.2-fold (0.08 log units) below; the range from low to high includes it.
By their numbers in this assay, from the lowest: compounds 1, 2, 4 and 3 (each within the scatter of the next).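

In this assay, 3-methoxyphenyl in place of 4-methoxyphenyl on the carbonyl carbon gives a 1.2-fold higher number from compound 1 to compound 4 (0.09 log units; within the scatter), so this first comparison of two places for the methoxy group on the ring shows no difference that can be read. Set against the halogen-bearing rings, the same group gives a 1.3-fold lower number from compound 3 to compound 4 (0.10 log units; within the scatter) and no change at the digits printed from compound 2 to compound 4 (within the scatter), which leaves all four compounds within the scatter of one another and extends the flat picture to a group with a different place on the ring. Nothing available here offers an explanation for this flatness.

As far as these compounds go, all four groups at this position are phenyl rings carrying a single methoxy or halogen, so it remains open whether the position tolerates anything further afield. An amine or a carboxylic acid on that ring, or a longer chain in its place, could still move the number.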